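The compounds below may be only part of what the source reports. "The series", "measured", "known", "first", "only" and "open" are said of these compounds alone.

Compound 1 `CC(C)Oc1ccc(C2CC(c3ccc(O)cc3)=NN2C(=O)c2cccnc2)cc1`: 45400 nM
Compound 2 `COc1ccc(C2CC(c3ccc(O)cc3)=NN2C(=O)c2cccnc2)cc1C`: 44800 nM
Compound 3 `Cc1cc(C)c(C2CC(c3ccc(O)cc3)=NN2C(=O)c2cccnc2)c(C)c1`: 54500 nM

In an ADME assay on HepG2 cells (Homo sapiens) for cytotoxicity, read by MTT assay, with a stated time of 7 days (on this read-out lower numbers stand for stronger inhibition and higher numbers for weaker inhibition), compound 2 gives the smallest of the three numbers, but that standing carries no weight: the step of a 1.0-fold lower number from compound 1 to compound 2 (0.01 log units; within the scatter) and the step of a 1.2-fold higher number from compound 2 to compound 3 (0.09 log units; within the scatter) both lie within the scatter, as does a 1.2-fold higher number from compound 1 to compound 3 (0.08 log units; within the scatter). Every swap measured so far changes only the aryl group on the saturated ring carbon, and none of them moves the read-out beyond the noise.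

Compound 4 `O=C(c1cccnc1)N1N=C(c2ccc(O)cc2)CC1c1ccccc1Cl` continues this series with 2-chlorophenyl in place of 4-methoxy-3-methylphenyl on a saturated ring carbon. The three measured steps are the ones that bear on it, and each was flat. On that basis the step from compound 2 to compound 4 is expected to be a 1.0-fold higher number from compound 2 to compound 4 (0.01 log units; within the scatter), which is to say no change beyond the scatter in this assay. Compound 4 is therefore estimated at 46000 nM, with a range from 25000 nM to 90000 nM.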

Compound 4, half-maximal inhibitory concentration: 47700 nM
Estimate against measurement, compound 4: 1.0-fold (0.02 log units) below; the range from low to high includes it.
By their numbers in this assay, from the lowest: compounds 2, 1, 4 and 3 (each within the scatter of the next).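

Going by these compounds alone, replacing 4-methoxy-3-methylphenyl (9 heavy atoms, 1 hydrogen-bond acceptor) with 2-chlorophenyl (7 heavy atoms, 0 hydrogen-bond acceptors) puts a chlorine on the saturated ring carbon for the first time, yet this assay shows no real shift (a 1.1-fold higher number from compound 2 to compound 4 (0.03 log units; within the scatter)). The comparisons with the other two aryl groups are just as flat (a 1.1-fold lower number from compound 3 to compound 4 (0.06 log units; within the scatter); a 1.1-fold higher number from compound 1 to compound 4 (0.02 log units; within the scatter)), so all four groups at this position, with or without an ether oxygen or a chlorine, stand within the scatter of one another. Nothing at hand accounts for this flat result.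

On these data alone, all four compounds carry a carbon-only aromatic ring at this position, so it remains open whether a cyclohexyl ring, an aminomethyl group or a carboxylic acid there would move the number. The 4-hydroxyphenyl and (pyridin-3-yl)carbonyl groups are also constant throughout, leaving their contribution unknown.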